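Shifting the Chlorine Around the Aryl Ring of Compound 1

The source may report more compounds than this note shows. Statements on the series, on what has been measured and on what is new or still open speak of the compounds shown alone.

Measured compounds:
compound 1, `O=C(NO)c1ccc(NCc2nc(-c3ccc(Cl)cc3)nn2-c2ccccc2)cc1`: 67.2%
compound 2, `NNC(=O)c1ccc(NCc2nc(-c3ccccc3)nn2-c2ccccc2)cc1`: 10%
compound 3, `O=C(NO)c1ccc(NCc2nc(-c3ccccc3)nn2-c2ccc(C(F)(F)F)cc2)cc1`: 38.9%

Of the compounds shown here, three have been tested in an assay on Sf9 cells for inhibition of protein deacetylase HDAC6 (Homo sapiens), read by fluorescence, with a stated time of 40 min, tested at 100 nM; on this read-out lower numbers stand for less inhibition and higher numbers for more inhibition at the one concentration tested (going by the name of the read-out). Compound 1 gives 67.2% and stands highest of the three. Compound 3 gives 38.9%, a value that lies beyond the scatter below compound 1, and compound 2 gives 10%, further still below it. No pair among these three differs in a single place, so no single-point step is available within the measured set.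

Compound 4, `O=C(NO)c1ccc(NCc2nc(-c3ccccc3Cl)nn2-c2ccccc2)cc1`, has not yet been measured. It differs from compound 1 by one change, (2-chlorophenyl in place of 4-chlorophenyl on an aromatic carbon). For the measured compounds named here, since no measured pair speaks to this change, the expectation rests on compound 1 alone. The step of a number 12.2 percentage points lower from compound 1 to compound 4 (beyond the scatter) is expected to be a modest decrease, with a real chance that it falls within the scatter. Compound 4 is expected to give about 55%, in a range from 30% to 75%.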

Compound 4, a percentage reported as inhibition, at one concentration (the size of the read-out at that concentration, not a potency): 75%
For compound 4 the middle estimate is 20 percentage points below the measured one; measured number inside the range.
By their numbers in this assay, from the lowest: compound 2; then compound 3; then compounds 1 and 4 (each within the scatter of the next).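

In this assay, for the compounds shown here, the change from 4-chlorophenyl to 2-chlorophenyl on this aromatic carbon gives the first single-place step (a number 7.8 percentage points higher from compound 1 to compound 4 (within the scatter)). The two placements of the chlorine on this phenyl ring therefore cannot be told apart at the one concentration tested, and the 4-chlorophenyl group is not needed to hold the read-out at the level of compound 1. Nothing measured here explains why the two placements read alike.

As far as these compounds go, whether a fluorine, a methoxy group or an amine in place of the chlorine on this phenyl ring would read the same remains open. The compounds shown also hold no pair that sets either chlorophenyl group against an unsubstituted phenyl at this place, so what the chlorine itself contributes is unknown.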